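Methoxy in place of hydrogen on the benzoyl group

This account rests on a few compounds, and the source may have more. Where it says the series, first, only, none or still open, it means among the compounds named here.

Compound 1 `Cc1nc(N)c2nc(-c3ccccc3)sc2n1`: > 30000 nM
Compound 2 `Cc1ccc(-c2nc(N)c3nc(-c4ccco4)sc3n2)o1`: > 30000 nM
Compound 3 `Cc1nc(NC(=O)c2ccccc2)c2nc(-c3ccccc3)sc2n1`: > 30000 nM

Of the compounds shown here, three sharing one core have been measured in a functional assay on CHO cells for antagonist activity at adenosine receptor A2b (Homo sapiens), read by cAMP accumulation, with a stated time of 10 min; a lower number here means a stronger inhibitor, a higher number a weaker inhibitor. Compound 1 `Cc1nc(N)c2nc(-c3ccccc3)sc2n1` gives > 30000 nM, which is a limit of the assay and not a number. Compound 2 `Cc1ccc(-c2nc(N)c3nc(-c4ccco4)sc3n2)o1`, which carries a methylfuranyl and a furanyl group, gives > 30000 nM, again a limit. Compound 3 `Cc1nc(NC(=O)c2ccccc2)c2nc(-c3ccccc3)sc2n1` gives > 30000 nM, also a limit. The one change among these that can be paired, a step that the two limits leave unreadable from compound 1 to compound 3, leaves its size unreadable, since both ends sit at the limit (the limit of > 30000 nM in this assay, at which 3 of the 3 values shown sit). Compound 3 therefore stands only on a limit, as do the two others.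

Compound 4 `COc1ccc(C(=O)Nc2nc(C)nc3sc(-c4ccccc4)nc23)cc1` differs from compound 3 by methoxy in place of hydrogen on an aromatic carbon. For the measured compounds named here, no measured step bears on this change; the only paired step is unreadable, so no direction beyond the scatter can be argued from the numbers. Compound 4 is expected to stay near the limit, with an estimated 30000 nM between 5000 nM and 100000 nM, an expected step of a number no higher from compound 3 to compound 4 (the limit leaves the size open).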

Compound 4, half-maximal inhibitory concentration: > 30000 nM
Compound 4 gave a limit, no number; the forecaster's own chance of this, stated with the estimate: 70%; the middle value lies on the limit itself.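

The step from compound 3 to compound 4 cannot be read, as both values are limits and not numbers: the limit of > 30000 nM in this assay, at which 4 of the 4 values shown sit. The compounds shown leave open whether methoxy in place of hydrogen, or any other change among them, alters inhibition at all.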